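Trimming the Amide Side Chain: Compound 2 to Compound 4

This account rests on a few compounds, and the source may have more. Where it says the series, first, only, none or still open, it means among the compounds named here.

Compound 1 `CC[C@@H]1C(=O)N(C)c2cnc(Nc3ccc(S(N)(=O)=O)cc3)nc2N1C1CCCC1` — 317 nM
Compound 2 `CCC1C(=O)N(C)c2cnc(-n3ccc4cc(C(=O)NCC(C)C)ccc43)nc2N1c1ccn(C)n1` — 4970 nM
Compound 3 `CCC1C(=O)N(C)c2cnc(Nc3ccc(S(N)(=O)=O)cc3)nc2N1c1ccn(C)n1` — 12600 nM

In a functional assay on HeLa cells (Homo sapiens) for antiproliferative activity, read by CCK-8 assay, with a stated time of 72 h (on this read-out lower numbers stand for stronger inhibition of growth and higher numbers for weaker inhibition of growth), compound 2 stands second highest of the three numbers. Its nearest neighbour is compound 3, whose number is higher by more than the scatter, while compound 1 lies furthest away with a markedly lower number. Compound 4 `CCNC(=O)c1ccc2c(ccn2-c2ncc3c(n2)N(c2ccn(C)n2)C(CC)C(=O)N3C)c1` differs from compound 2 by methyl in place of isopropyl on a saturated chain carbon bound to an amide-type nitrogen; cut one bond further out, the same difference reads isobutylcarbamoyl to ethylcarbamoyl. Going by the values given here, no measured pair shows this exact change, so its size cannot be read from the data. The step from compound 2 to compound 4 is expected to stay within the scatter, with no clear direction a 1.0-fold higher number from compound 2 to compound 4 (0.00 log units; within the scatter). Compound 4 is therefore estimated at 5000 nM, with a range from 2000 nM to 12500 nM.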

Compound 4, concentration for 50% growth inhibition: 11100 nM
Beside the measured number, compound 4's estimate is 2.2-fold (0.35 log units) below it; low and high end bracket the measured number.
By their numbers in this assay, from the lowest: compound 1; then compound 2; then compounds 4 and 3 (each within the scatter of the next).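

In this assay, going by these compounds alone, the step from isobutylcarbamoyl to ethylcarbamoyl gives a 2.2-fold higher number from compound 2 to compound 4 (0.35 log units; beyond the scatter) and so provides the first measured reading at this position. The side chain is not silent in this read-out: the change is modest, but the shorter chain goes with weaker inhibition of growth. No evidence is available here to explain this step.

With only two chains compared, no trend along the chain can be drawn. As far as these compounds go, whether a longer chain, an amine or a carboxylic acid in place of isobutyl would give a lower number remains open.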